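The source may hold more compounds than are shown below. What is called first, only, known or untested is meant among the compounds shown, and "the series" means these compounds.

Measured compounds:
- compound 1, `COc1ccc(CN(C(=O)CCl)c2cc(OC)c(OC)c(OC)c2)cc1O`, 84 nM in a functional assay on MGC-803 cells (Homo sapiens) for inhibition, read by MTT assay, with a stated time of 48 h; on this read-out lower numbers stand for stronger inhibition and higher numbers for weaker inhibition
- compound 2, `COc1cc(NCc2cccc(O)c2)cc(OC)c1OC`, 57600 nM in this assay
- compound 3, `C/C=C/C(=O)N(Cc1ccc(OC)cc1)c1cc(OC)c(OC)c(OC)c1`, 450 nM in this assay

Among these three, compound 1 gives the lowest number in this assay, and its gaps to compound 3 and to compound 2 both lie beyond the usual scatter, so on this read-out compound 1 is the most potent of the three. Compound 2, which carries no carbonyl group on its nitrogen, gives by far the highest number.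

Compound 4, `COc1ccc(CN(C(=O)CO)c2cc(OC)c(OC)c(OC)c2)cc1O`, has not yet been measured. It differs from compound 1 in one place: hydroxy in place of chloro on a saturated chain carbon bound to a carbonyl carbon. Among the compounds with values here, no pair of measured compounds differs only in this way, so the data hold no direct guide to the size of this step. The expectation for compound 4 is a clear loss of potency, with a step of a 24-fold higher number from compound 1 to compound 4 (1.38 log units; beyond the scatter) that is expected to lie beyond the scatter. Compound 4 is therefore estimated at 2000 nM, within a range from 300 nM to 15000 nM in this assay.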

Compound 4, half-maximal inhibitory concentration: 160 nM
Estimate against measurement, compound 4: 13-fold (1.10 log units) above, and the stated range ends above it.
By their numbers in this assay, from the lowest: compounds 1 and 4 (each within the scatter of the next); then compound 3; then compound 2.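

In this assay, hydroxy in place of chloro on a saturated chain carbon bound to a carbonyl carbon gives a 1.9-fold higher number from compound 1 to compound 4 (0.28 log units; within the scatter), so on this read-out the two compounds cannot be told apart. For this pair, then, chlorine at this place is not required for a number of this size, and the change adds a hydrogen-bond donor and a hydrogen-bond acceptor without a step beyond the scatter. Nothing available explains why this change leaves the number within the scatter.

Going by these compounds, how an amine, a methoxy group or a plain methyl group at this same carbon would read remains open, as does the effect of a longer chain in place of hydroxymethyl. This single pair also cannot show whether the same swap would behave alike on a different core.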